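Ether side-chain change from compound 3 to compound 4

This account rests on a few compounds, and the source may have more. Where it says the series, first, only, none or still open, it means among the compounds named here.

Compound 1 `Nc1cc2c(-n3nc(-c4ccccn4)nc3N)ncnc2cc1Cl` was tested in an assay on MCF7 cells for inhibition of Serine-protein kinase ATM (Homo sapiens), read by immunofluorescence, with a stated time of 1 h; a lower number here means a stronger inhibitor, a higher number a weaker inhibitor; in this assay compound 1 gives only a limit, > 40000 nM, and is set aside for the ranking. Compound 2 `COc1cc2ncnc(-n3nc(-c4ccccn4)nc3N)c2cc1[N+](=O)[O-]` gives 31100 nM in this assay, and compound 3 `CCN(CC)C(=O)COc1cc2c(-n3nc(-c4ccccn4)nc3N)ncnc2cc1OC` gives 5300 nM. Among the compounds with values here, the single measured step, a 5.9-fold lower number from compound 2 to compound 3 (0.77 log units; beyond the scatter), lies beyond the scatter, so compound 3 holds the lowest of the two numbers, with compound 2 next.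

Compound 4 `COc1cc2ncnc(-n3nc(-c4ccccn4)nc3N)c2cc1OCCCNC(=O)OCC(F)(F)F` differs from compound 3 by 2-(((2,2,2-trifluoroethoxy)carbonyl)amino)ethyl in place of diethylcarbamoyl on a saturated chain carbon bound to an oxygen on an aromatic ring. Within the data shown here, no measured step touches this part of the molecule: the step from compound 2 to compound 3 exchanges the group on the aromatic carbon itself, and the limit of > 40000 nM in this assay, at which 1 of the 3 values shown sits, concerns compound 1 alone. The chain carried on the aromatic oxygen is therefore untested, and the expectation rests on the two compounds bearing such a chain being read as one group. Compound 4 is expected to sit near compound 3, with a 1.2-fold lower number from compound 3 to compound 4 (0.07 log units; within the scatter) not beyond the scatter. The estimated value for compound 4 in this assay is 4500 nM, within a range from 1500 nM to 15000 nM.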

Compound 4, half-maximal inhibitory concentration: 1200 nM
Compound 4: middle estimate off by 3.8-fold (0.57 log units), on the high side, outside the stated range (below it).
By their numbers in this assay, from the lowest: compound 4; then compound 3; then compound 2. At a limit, above all of these: compound 1.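

The side chain on the aromatic oxygen matters in this assay: 2-(((2,2,2-trifluoroethoxy)carbonyl)amino)ethyl in place of diethylcarbamoyl gives a 4.4-fold lower number from compound 3 to compound 4 (0.65 log units; beyond the scatter). Within the data shown here, the earlier step concerned only the group on the aromatic carbon itself, so this is the first reading of a change further out along the ether chain. The change is not a single variable, as the chain end, the chain length and the amide hydrogen all differ together, and no measurement shown here assigns the step to any one of them.

Open is which of these parts carries the step, since the compounds shown offer no comparison with a plain terminal amine, a carboxylic acid or a non-fluorinated ethoxycarbonylamino chain end. Also open, going by these compounds, is how a longer chain on the same oxygen would read.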